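Amide analogues on the shared core: compound 3 to compound 4

This account rests on a few compounds, and the source may have more. Where it says the series, first, only, none or still open, it means among the compounds named here.

Measured so far:
compound 1 `Cc1cccc(-c2noc(C3CN(S(=O)(=O)c4ccc(Cl)cc4)C3)n2)c1` — 1100 nM
compound 2 `O=C(C1CCC(F)(F)CC1)N1CC(c2nc(-c3cccc(Cl)c3)no2)C1` — > 10000 nM
compound 3 `COC1CCN(C(=O)N2CC(c3nc(-c4cccc(Cl)c4)no3)C2)CC1` — > 10000 nM

Going by the values given here, in an assay on HEK293 cells for negative allosteric modulation of metabotropic glutamate receptor 5 (Homo sapiens), read by FLIPR (on this read-out higher numbers stand for weaker inhibition and lower numbers for stronger inhibition), compound 1 gives 1100 nM and is the only compound of the three with a number rather than a limit. For compound 2 the assay reports only a limit, > 10000 nM. For compound 3 the assay likewise reports only a limit, > 10000 nM. Compound 3 thus sits at the limit of > 10000 nM in this assay, at which 2 of the 3 values shown sit, alongside compound 2. Among the compounds with values here, the single measured step that reaches compound 3, a step that the two limits leave unreadable from compound 2 to compound 3, runs from one limit to another and gives no readable size, so the exchange of 4,4-difluorocyclohexyl for 4-methoxypiperidin-1-yl on the carbonyl carbon tells nothing about the direction of the series.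

Compound 4 `CC1CCN(C(=O)N2CC(c3nc(-c4cccc(Cl)c4)no3)C2)CC1` is the next member. It differs from compound 3 by methyl in place of methoxy on a saturated ring carbon. Within the data shown here, no measured step covers a change of this kind, and the only step that touches compound 3 is unreadable, so no measured evidence points either way in this assay. Both amide analogues so far sit at the limit, and compound 4 keeps the amide on the carbonyl carbon. Compound 4 is therefore expected to stay close to the limit, the estimate being 12000 nM with a range of 3000 nM to 40000 nM. The step this estimate means is a step that the limit leaves unreadable from compound 3 to compound 4, which is expected to lie within the scatter, with the assay most likely again reporting only a limit.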

Compound 4, half-maximal inhibitory concentration: > 10000 nM
Compound 4: a limit, no number (the forecaster's own chance of this, stated with the estimate: 70%); the middle value does not contradict the limit.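

In this assay compound 4 gives > 10000 nM, which is a limit. Its steps from compound 2 and from compound 3 run from one limit to another, so neither can be read. The compounds shown leave open whether any amide analogue on the shared core gives a number rather than a limit, the amides so far all sitting at one value: the limit of > 10000 nM in this assay, at which 3 of the 4 values shown sit.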